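A few compounds are considered here, and "the series" means these few. Any claim that something is new, unique, unknown or untested is made for them only; others in the source may bear on it.

Measured so far:
Compound 1, `O=C(O)CNc1cccc(CNc2cc(C(F)(F)F)cc3[nH]ncc23)c1`, gives a limit in an assay for inhibition of Tryptophan 2,3-dioxygenase (Homo sapiens), with stated times of 10 min and 60 min (on this read-out lower numbers stand for stronger inhibition and higher numbers for weaker inhibition), namely > 100000 nM.
Compound 2, `COc1cc(CNc2cc(Br)cc3[nH]ncc23)c([N+](=O)[O-])cc1OC`, gives 1040 nM in this assay.
Compound 3, `FC(F)(F)c1cc(NC[C@H]2CCCN2)c2cn[nH]c2c1`, gives 6090 nM in this assay.

Compound 3 stands as the higher of the two numbers actually measured, so it is the weaker of the two inhibitors with a number; compound 2 sits well below it, and that gap is beyond the usual scatter. The value of compound 1 is only a limit of the assay, not a number, so it cannot be ranked against the other two.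

Compound 4, `FC(F)(F)c1cc(NCc2cccc(Br)c2)c2cn[nH]c2c1`, has not yet been measured. It differs from compound 3 in one place: 3-bromophenyl in place of pyrrolidin-2-yl on a saturated chain carbon bound to a nitrogen on an aromatic ring. The shared core and the nitrogen that links it to the side chain are unchanged; only the group on the saturated chain carbon is swapped.

Within the data shown here, no measured pair shows this particular change, so the expected step rests on little. Compound 2 shows that a benzylic group on this kind of nitrogen can give a number well below that of compound 3, while compound 1 shows that a benzylic group can also fall outside the measurable range. On balance compound 4 is expected to land somewhat below compound 3, a step of a 2.4-fold lower number from compound 3 to compound 4 (0.39 log units; beyond the scatter), with wide uncertainty. The estimate for compound 4 in this assay is 2500 nM, with a range from 500 nM to 15000 nM.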

Compound 4, half-maximal inhibitory concentration: 19100 nM
The estimate for compound 4 lay 7.6-fold (0.88 log units) below the measured number; measured number above the stated range.
By their numbers in this assay, from the lowest: compound 2; then compound 3; then compound 4. At a limit, above all of these: compound 1.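

At the position on a saturated chain carbon bound to a nitrogen on an aromatic ring, 3-bromophenyl, with no hydrogen-bond donor or acceptor, in place of pyrrolidin-2-yl, with one of each, gives a direct reading in this assay: a 3.1-fold higher number from compound 3 to compound 4 (0.50 log units; beyond the scatter). This shows that, for this pair, the change weakens inhibition by a modest step, whereas on an aromatic carbon, bromo in place of (carboxymethyl)amino goes the other way, with an at least 5.2-fold lower number from compound 1 to compound 4 (0.71 log units; beyond the scatter). The value of compound 1 is a limit and not a number, so this second step gives only a minimum size: the limit of > 100000 nM in this assay, at which 1 of the 4 values shown sits.

Among these compounds, the single step from compound 3 to compound 4 changes several things at once, so it cannot say whether the bromine, the aromatic ring or the loss of the ring nitrogen and its stereocentre matters most, and a plain phenyl, a piperidin-2-yl or an open-chain amine on the same carbon would help to separate these. The compounds shown also leave open whether the mirror-image pyrrolidin-2-yl behaves like the one in compound 3, and whether a carboxylic acid placed elsewhere would fare any better.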